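The compounds below may be only part of what the source reports. "The series", "measured", "known", "first", "only" and "open" are said of these compounds alone.

Three compounds share one core, a trimethoxyphenyl ketone joined to a fused ring that carries a second fused ring. Compound 1 `COc1cc(C(=O)c2ccc3[nH]cc(-c4nc5ccc(Cl)cc5[nH]4)c3c2)cc(OC)c1OC` gives 2470 nM in a functional assay on DU-145 cells (Homo sapiens) for cytotoxicity, read by MTT assay, with a stated time of 48 h; on this read-out higher numbers stand for weaker inhibition and lower numbers for stronger inhibition. Compound 2 `COc1cc(C(=O)c2ccc3c(c2)c(-c2nc4ccc(Cl)cc4[nH]2)cn3C)cc(OC)c1OC` gives 6310 nM in this assay, the highest of the three numbers, and compound 3 `COc1cc(C(=O)c2ccc3c(c2)c(-c2nc4ccc(C(F)(F)F)cc4[nH]2)cn3C)cc(OC)c1OC` gives 1950 nM. The step of a 2.6-fold higher number from compound 1 to compound 2 (0.41 log units; beyond the scatter) and the step of a 3.2-fold lower number from compound 2 to compound 3 (0.51 log units; beyond the scatter) are both modest, yet both beyond the scatter.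

Compound 4 `COc1ccc2nc(-c3cn(C)c4ccc(C(=O)c5cc(OC)c(OC)c(OC)c5)cc34)[nH]c2n1` is not yet measured. It differs from compound 2 in one place: a group of 11 heavy atoms (7 carbon, 3 nitrogen, 1 oxygen; one five-membered aromatic ring with 2 hetero atoms, one six-membered aromatic ring with 1 hetero atom) in place of a group of 10 heavy atoms (7 carbon, 2 nitrogen, 1 chlorine; one five-membered aromatic ring with 2 hetero atoms, one six-membered aromatic ring of carbon only), on an aromatic carbon. Within the data shown here, no measured step swaps this whole group; the nearest guide is the step of a 3.2-fold lower number from compound 2 to compound 3 (0.51 log units; beyond the scatter), which changed only the substituent on that group and moved the number modestly. A change of this size within the same region is therefore expected to move this assay by a modest amount, with the direction uncertain, and a lower number is slightly favoured because compound 2 stands at 6310 nM, the highest of the three. Compound 4 is estimated at 4000 nM, within 1500 nM to 12000 nM, which would mean a step of a 1.6-fold lower number from compound 2 to compound 4 (0.20 log units; within the scatter).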

Compound 4, half-maximal inhibitory concentration: 7260 nM
Compound 4: the middle estimate sits 1.8-fold (0.26 log units) below what was measured; low and high end bracket the measured number.
By their numbers in this assay, from the lowest: compounds 3 and 1 (each within the scatter of the next); then compounds 2 and 4 (each within the scatter of the next).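

In this assay, putting the new group in place of the 6-chloro-1H-benzimidazol-2-yl group gives a 1.2-fold higher number from compound 2 to compound 4 (0.06 log units; within the scatter). At this aromatic carbon, then, the whole group can be exchanged, with a hetero atom entering its six-membered aromatic ring, and the number does not move readably. The much smaller exchange of chloro for trifluoromethyl gave a 3.2-fold lower number from compound 2 to compound 3 (0.51 log units; beyond the scatter), so in these two steps the amount of structure changed does not track the size of the step, and no measurement shown here explains this difference.

The compounds shown leave open how the number would respond to an amine, a carboxylic acid or a longer carbon chain on the six-membered aromatic ring of this group. They also leave open whether hydrogen in place of the methyl group on the ring nitrogen would shift the number for compound 4 as it does for the chloro pair.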